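Removing a Methyl from a Benzyl Arm: Expected Cell Tolerance

This account rests on a few compounds, and the source may have more. Where it says the series, first, only, none or still open, it means among the compounds named here.

Measured so far:
Compound 1, `O=C1c2ccccc2N(Cc2ccc([N+](=O)[O-])cc2)S(=O)(=O)N1Cc1ccc([N+](=O)[O-])cc1`: 53000 nM in a functional assay on MRC5 cells (Homo sapiens); a higher number here means that more compound is tolerated, a lower number that less compound is tolerated
Compound 2, `Cc1ccc(CN2c3ccccc3C(=O)N(Cc3ccccc3)S2(=O)=O)cc1`: 63000 nM in this assay

Both compounds share the same core and differ only in their two benzyl-type arms. In this assay compound 2 gives 63000 nM, and compound 1 gives 53000 nM; the gap between them lies within the scatter, so the two cannot be told apart on these numbers. Compound 3, `O=C1c2ccccc2N(Cc2ccccc2)S(=O)(=O)N1Cc1ccccc1`, has not yet been measured. It differs from compound 2 by hydrogen in place of methyl on an aromatic carbon. Among the compounds with values here, no measured pair shows this change on its own, so no measured step tells its size. Given how little the two measured numbers differ, the step is expected to be small, a 1.1-fold lower number from compound 2 to compound 3 (0.02 log units; within the scatter), with nothing beyond the scatter in either direction. Compound 3 is therefore estimated to give 60000 nM in this assay, within a range of 30000 nM to 120000 nM.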

Compound 3, half-maximal cytotoxic concentration: 66000 nM
Beside the measured number, compound 3's estimate is 1.1-fold (0.04 log units) below it, and the stated range covers the measured number.
By their numbers in this assay, from the lowest: compounds 1, 2 and 3 (each within the scatter of the next).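

Within the data shown here, this is the first time the swap of methyl for hydrogen on this aromatic carbon can be read on its own, and it comes to a 1.0-fold higher number from compound 2 to compound 3 (0.02 log units; within the scatter) in this assay. Going from the 4-methylbenzyl arm to the benzyl arm therefore produces no change that can be told apart from the scatter of repeated measurements, at least in this pair and in these cells. Nothing shown here speaks to the reason for this result.

The compounds shown leave open whether an amine, a carboxylic acid or a longer chain on the same aromatic carbon would also stay within the scatter. They also leave open whether the same swap would behave alike on the other benzyl arm.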